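This account rests on a few compounds, and the source may have more. Where it says the series, first, only, none or still open, it means among the compounds named here.

Compound 1 `C=CCOc1cc(OC)c(C(=O)/C=C/c2ccccc2Br)c(OCC=C)c1`: 5400 nM
Compound 2 `COc1cc(O)cc(O)c1C(=O)/C=C/c1ccccc1Br`: 14600 nM

Going by the values given here, in a toxicity assay on cells (Macrophage, Mus musculus, strain BALB/c) for cytotoxicity, read by MTT assay (on this read-out lower numbers stand for stronger inhibition and higher numbers for weaker inhibition), compound 1 gives 5400 nM, the lower of the two numbers measured so far. Compound 2 gives 14600 nM, and that gap lies beyond the usual scatter.

Compound 3 `C=CCOc1cc(OC)c(C(=O)/C=C/c2ccc(Cl)cc2)c(OCC=C)c1` keeps the core of compound 1 and changes one group: 4-chlorophenyl in place of 2-bromophenyl on a double-bonded chain carbon bound to a double-bonded chain carbon. Put simply, 4-chlorophenyl takes the place of 2-bromophenyl, and the two groups match in the counts shown. Among the compounds with values here, no measured pair of compounds shows what this swap does, so the expectation is only a cautious one: no step beyond the scatter in this assay, and no firm direction. The estimated change is a 1.1-fold higher number from compound 1 to compound 3 (0.05 log units; within the scatter). Compound 3 is expected at 6000 nM, with an estimated range of 2500 nM to 15000 nM.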

Compound 3, half-maximal inhibitory concentration: 13000 nM
The estimate for compound 3 lay 2.2-fold (0.34 log units) below the measured number; low and high end bracket the measured number.
By their numbers in this assay, from the lowest: compound 1; then compounds 3 and 2 (each within the scatter of the next).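

In this assay the group at this place on the chain matters: 4-chlorophenyl in place of 2-bromophenyl gives a 2.4-fold higher number from compound 1 to compound 3 (0.38 log units; beyond the scatter) and so weaker inhibition of the cells. The two groups match in heavy atoms, donors and acceptors, so a swap that leaves those counts unchanged can still move the number beyond the usual scatter, which compound 1 and compound 2 could not show, as they differ in more than one place. Nothing measured here gives a reason for this step.

As far as these compounds go, the swap changes the halogen and its place on the ring together, so it stays open which of the two carries the step; 4-bromophenyl or 2-chlorophenyl would separate them. Also open, from the compounds shown here alone, is how the number responds to a group without halogen, such as plain phenyl.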